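The compounds below may be only part of what the source reports. "The series", "measured", "known", "first", "only" and "open" are said of these compounds alone.

For the measured compounds named here, compound 1 `Cn1c(=O)c(S(=O)(=O)c2ccc(F)cc2F)cc2cnc(Nc3ccc4[nH]c(C(=O)O)cc4c3)nc21` stands at the weaker end of the two numbers so far: in a functional assay on DU-145 cells (Homo sapiens) for inhibition, read by trypan blue exclusion, with a stated time of 72 h (a higher number here means a weaker inhibitor, a lower number a stronger inhibitor), compound 1 gives 10000 nM, the highest value measured. Going by the values given here, the only other measured compound, compound 2 `O=c1c(S(=O)(=O)c2ccc(F)cc2F)cc2cnc(Nc3ccc4[nH]ccc4c3)nc2n1C1CC1`, gives 500 nM in this assay, a gap that lies beyond the scatter; compound 2 differs from compound 1 in more than one place, so no single step is drawn between them.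

Compound 3 `Cn1c(=O)c(S(=O)(=O)c2ccc(F)cc2F)cc2cnc(NCc3ccc4[nH]ccc4c3)nc21` has not yet been measured. It is derived from compound 1 by one change, ((1H-indol-5-yl)methyl in place of 2-carboxy-1H-indol-5-yl on a nitrogen on an aromatic ring).

Since compound 2 shows that this scaffold can reach 500 nM without the 2-carboxy group, compound 3 is expected to move in the stronger direction, with an estimated step of a 5.0-fold lower number from compound 1 to compound 3 (0.70 log units; beyond the scatter) in this assay. Compound 3 is therefore estimated at 2000 nM, with a range from 500 nM to 8000 nM.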

Compound 3, half-maximal inhibitory concentration: 100000 nM
Compound 3: the middle estimate sits 50-fold (1.70 log units) below what was measured, and the stated range ends below it.
By their numbers in this assay, from the lowest: compound 2; then compound 1; then compound 3.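

In this assay, placing (1H-indol-5-yl)methyl in place of 2-carboxy-1H-indol-5-yl on a nitrogen on an aromatic ring gives a 10-fold higher number from compound 1 to compound 3 (1.00 log units; beyond the scatter), so the first single-place step available runs towards weaker inhibition. The carboxy group and the direct attachment of the indole both go in this one change, which means the step belongs to the pair of groups as a whole and not to either alteration alone. No measurement at hand accounts for this step.

The carboxylic acid goes and a methyl link comes in the same step. The compounds shown do not tell these two alterations apart. Going by these compounds, a (2-carboxy-1H-indol-5-yl)methyl group, or a 1H-indol-5-yl group on the core of compound 1, would separate the two, and a primary amide in place of the carboxylic acid remains untested here.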